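The compounds below may be only part of what the source reports. "The series", "measured", "known", "first", "only" and "open" are said of these compounds alone.

Measured in a functional assay (Homo sapiens) for inhibition, read by sulforhodamine B assay, with a stated time of 3 days; a lower number here means a stronger inhibitor, a higher number a weaker inhibitor:
- compound 1 `CN(C)c1nc(N2CCNCC2)nc2nc(NCc3ccccc3)c(Cl)nc12`: 5900 nM
- compound 2 `CC(=O)N1CCN(c2nc(N3CCCC3)c3nc(Cl)c(NCc4ccccc4)nc3n2)CC1`: 13000 nM

With only these two values, compound 2 at 13000 nM holds the higher number, so it is the weaker inhibitor. Compound 1 at 5900 nM lies lower, and the gap between them is beyond the scatter.

Compound 3 `CN(C)c1nc(N2CCCC2)c2nc(Cl)c(NCc3ccccc3)nc2n1` is made from compound 2 by one change: dimethylamino in place of 4-acetylpiperazin-1-yl on an aromatic carbon. Dimethylamino stands in place of 4-acetylpiperazin-1-yl on an aromatic carbon, between two ring nitrogen atoms, and the pyrrolidin-1-yl group stays. For the measured compounds named here, no measured pair isolates this change, so the expectation has little support. Compound 1, which also carries a dimethylamino group, gives 5900 nM, and this is the only lean towards a lower number.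

In this assay, a modest step in that direction is expected, possibly not much beyond the scatter. The estimated change is a 1.9-fold lower number from compound 2 to compound 3 (0.27 log units; within the scatter). For compound 3 the expected value is 7000 nM, with an estimated range from 2000 nM to 25000 nM.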

Compound 3, half-maximal inhibitory concentration: 11800 nM
Estimate against measurement, compound 3: 1.7-fold (0.23 log units) below; the measured number falls inside the stated range.
By their numbers in this assay, from the lowest: compounds 1, 3 and 2 (each within the scatter of the next, the first and the last beyond it).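

In this assay, putting dimethylamino in place of 4-acetylpiperazin-1-yl on this aromatic carbon, between two ring nitrogen atoms, gives a 1.1-fold lower number from compound 2 to compound 3 (0.04 log units; within the scatter). With the pyrrolidin-1-yl group held constant, this read-out therefore does not separate the two groups, even though the substituent goes from 9 heavy atoms to 3 and loses its six-membered non-aromatic ring and its acetyl carbonyl; neither feature is needed to reach the level of compound 2 at this position. No measured evidence on the compounds is available to account for this result.

For the compounds shown here, this single step covers only one pair of substituents in one setting, and compound 1 differs from compound 3 in more than one place, so it cannot show whether the same holds with another group in place of pyrrolidin-1-yl. As far as these compounds go, whether a morpholin-4-yl ring, a carboxylic acid or a longer aminoalkyl chain on this carbon would shift the number beyond the scatter remains open.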